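The source may hold more compounds than are shown below. What is called first, only, known or untested is meant among the compounds shown, and "the series" means these compounds.

Working notes on the aryl-amino series sharing one core.

Compound 1 `Cc1ccc(NC2=CC(=O)c3nc4n(c3C2=O)[C@H]2OC[C@@H](O)[C@H]2OC4)cc1` carries a 4-methylphenyl on the amine nitrogen; in a functional assay on MGC-803 cells (Homo sapiens) for inhibition, read by sulforhodamine B assay (on this read-out lower numbers stand for stronger inhibition and higher numbers for weaker inhibition), compound 1 gives 1420 nM. Compound 2 `COc1cccc(NC2=CC(=O)c3nc4n(c3C2=O)[C@H]2OC[C@@H](O)[C@H]2OC4)c1` has the 3-methoxyphenyl there, and in this assay compound 2 gives 1780 nM. Compound 3 `COc1ccc(NC2=CC(=O)c3nc4n(c3C2=O)[C@H]2OC[C@@H](O)[C@H]2OC4)cc1` carries the 4-methoxyphenyl, and in this assay compound 3 gives 1680 nM. On these numbers compound 3 sits between the other two, and every gap is within the scatter: a 1.2-fold higher number from compound 1 to compound 3 (0.07 log units; within the scatter), a 1.1-fold lower number from compound 2 to compound 3 (0.03 log units; within the scatter) and, for completeness, a 1.3-fold higher number from compound 1 to compound 2 (0.10 log units; within the scatter).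

Compound 4 `O=C1C=C(Nc2cccc(F)c2)C(=O)c2c1nc1n2[C@H]2OC[C@@H](O)[C@H]2OC1` is the next member. The change from compound 3 is 3-fluorophenyl in place of 4-methoxyphenyl on an amine nitrogen. Among the measured compounds shown here, no measured step covers a fluorine on the phenyl, so the nearest guides are the exchanges of methyl for methoxy and of 3-methoxyphenyl for 4-methoxyphenyl, both of which moved the number by less than the scatter. The three aryl variants so far give no sign that the group on the amine nitrogen shifts this assay beyond the scatter, so the expectation for compound 4 is a step of a 1.0-fold higher number from compound 3 to compound 4 (0.01 log units; within the scatter), that is, no change beyond the scatter. Compound 4 is thus estimated at 1700 nM in this assay, with a range from 800 nM to 3600 nM.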

Compound 4, half-maximal inhibitory concentration: 2180 nM
Beside the measured number, compound 4's estimate is 1.3-fold (0.11 log units) below it; low and high end bracket the measured number.
By their numbers in this assay, from the lowest: compounds 1, 3, 2 and 4 (each within the scatter of the next).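

The series now includes a halogen on the phenyl ring, and the number does not move beyond the scatter. In this assay, the exchange on the amine nitrogen gives a 1.3-fold higher number from compound 3 to compound 4 (0.11 log units; within the scatter) and removes the hydrogen-bond acceptor of the 4-methoxyphenyl, while fluoro in place of methoxy on an aromatic carbon gives a 1.2-fold higher number from compound 2 to compound 4 (0.09 log units; within the scatter). The largest gap among these four compounds, a 1.5-fold higher number from compound 1 to compound 4 (0.19 log units; within the scatter) and still within the scatter, shows that methyl, methoxy and fluoro variants of the aryl group on this nitrogen cannot be told apart in this assay, and nothing available explains this flat response.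

Compound 3 and compound 4 differ in both the substituent and its printed position, so the shown compounds do not separate these two contributions. On these data alone, it remains open whether a carboxylic acid or an amine on the phenyl ring, or a longer alkyl chain in place of the phenyl ring on the nitrogen, would produce a step beyond the scatter.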